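The compounds below may be only part of what the source reports. "The series", "measured", "known", "first", "only" and "open" are said of these compounds alone.

In a functional assay on MCF7 cells (Homo sapiens) for cytotoxicity, read by MTT assay, with a stated time of 96 h (a lower number here means a stronger inhibitor, a higher number a weaker inhibitor), compound 1 `COc1cc(C(=O)c2cn(-c3cccc(Cl)c3)cc2-c2ccccc2)cc(OC)c1OC` gives 150 nM and compound 2 `COc1cc(C(=O)c2cn(-c3cccc([N+](=O)[O-])c3)cc2-c2ccccc2)cc(OC)c1OC` gives 550 nM as the higher of the two numbers. Compound 3 `COc1cccc(-n2cc(C(=O)c3cc(OC)c(OC)c(OC)c3)c(-c3ccccc3)c2)c1` is not yet measured and differs from compound 2 by methoxy in place of nitro on an aromatic carbon with methoxy in place of nitro on an aromatic carbon, meta to a large group. Among the measured compounds shown here, the one measured step at this place, nitro in place of chloro, is a 3.7-fold higher number from compound 1 to compound 2 (0.56 log units; beyond the scatter) and counts as modest and beyond the scatter. Losing nitro is therefore expected to bring a modest move toward a lower number. In this assay the expected step is a 2.2-fold lower number from compound 2 to compound 3 (0.34 log units; beyond the scatter) on this reasoning. Compound 3 is estimated at 250 nM with 80 nM to 750 nM as its expected range.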

Compound 3, half-maximal inhibitory concentration: 500 nM
Beside the measured number, compound 3's estimate is 2.0-fold (0.30 log units) below it, within the range that was stated.
By their numbers in this assay, from the lowest: compound 1; then compounds 3 and 2 (each within the scatter of the next).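

In this assay, methoxy in place of nitro gives a 1.1-fold lower number from compound 2 to compound 3 (0.04 log units; within the scatter), so the two groups cannot be told apart at this position on the aromatic ring. Chloro alone stands apart, since methoxy in its place gives a 3.3-fold higher number from compound 1 to compound 3 (0.52 log units; beyond the scatter), alongside the earlier 3.7-fold higher number from compound 1 to compound 2 (0.56 log units; beyond the scatter). Nothing measured here explains this difference. Going by these compounds, whether an amine or a carboxylic acid at this place would match chloro, or instead match nitro and methoxy, stays open. So does whether fluoro or bromo would keep the number of compound 1.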